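Enantiomer swap on the hydroxypropyl chain in a weak series

This account rests on a few compounds, and the source may have more. Where it says the series, first, only, none or still open, it means among the compounds named here.

Among the measured compounds shown here, compound 2 `Cc1ccc(NC(=O)c2ccc(C)c(C(F)(F)F)c2)cc1C#Cc1nn(C[C@@H](C)CO)c2ncnc(N)c12` is the only compound here with a number in an ADME assay on HepG2 cells (Homo sapiens) for antiproliferative activity, read by MTT assay, with a stated time of 72 h (a lower number here means a stronger inhibitor, a higher number a weaker inhibitor), where compound 2 gives 8300 nM. Compound 1 `Cc1ccc(NC(=O)c2cccc(C(F)(F)F)c2)cc1C#Cc1nn(C[C@H](C)CO)c2ncnc(N)c12` returns only a limit in this assay, namely > 10000 nM. For the measured compounds named here, with one of the two values sitting at the limit of > 10000 nM in this assay, at which 1 of the 2 values shown sits, no measured step between compounds can be drawn, and the series as a whole sits at the weak end of the assay. Compound 3 `Cc1ccc(NC(=O)c2ccc(C)c(C(F)(F)F)c2)cc1C#Cc1nn(C[C@H](C)CO)c2ncnc(N)c12` is the other enantiomer of compound 2: the two compounds have the same atoms and bonds and differ only in configuration as drawn: 1 of 1 stereo elements differ; a stereocentre at a saturated chain carbon is drawn R in compound 2 and S in compound 3. Going by the values given here, no step between two measured compounds is available, so the size of the change from compound 2 to compound 3 in this assay is not fixed by the data. Compound 1, which carries the same drawn configuration at that centre as compound 3, sits at the limit of > 10000 nM in this assay, at which 1 of the 2 values shown sits, so a drift toward weaker activity would not surprise, but nothing beyond the scatter is firmly expected. Compound 3 is therefore expected to give 10000 nM, between 4000 nM and 25000 nM. This corresponds to an estimated step of a 1.2-fold higher number from compound 2 to compound 3 (0.08 log units; within the scatter).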

Compound 3, half-maximal inhibitory concentration: > 10000 nM
Compound 3: only a limit was reported; the forecaster's own chance of this, stated with the estimate: 45%; the middle value lies on the limit itself.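

Drawing the saturated chain carbon S rather than R gives the first step in this series that can be stated at all: in this assay the change gives an at least 1.2-fold higher number from compound 2 to compound 3 (0.08 log units; that floor lies within the scatter) and only that floor can be read, with compound 3 returning a limit. Neither configuration at this centre takes the compound clear of the weak end of the assay, and no preference between the two enantiomers can be stated: the limit of > 10000 nM in this assay, at which 2 of the 3 values shown sit. The step from compound 1 to compound 3 cannot be read, as both values are limits.

On these data alone, whether an amine or a carboxylic acid in place of the hydroxy group, or a longer chain, would bring values clear of the limit stays open. As far as these compounds go, how the methyl on the aromatic carbon behaves with the chain drawn R also stays open.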